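Aryl variation on the benzylsulfanyl arm of a shared core

The compounds below may be only part of what the source reports. "The series", "measured", "known", "first", "only" and "open" are said of these compounds alone.

Measured so far:
compound 1 `Cc1ccc(CSc2nc3nc(C)cc(Nc4cc(-c5ccccc5)[nH]n4)n3n2)cc1` — 7290 nM
compound 2 `Cc1cc(Nc2cc(-c3ccccc3)[nH]n2)n2nc(SCc3csc4ccccc34)nc2n1` — 3470 nM
compound 3 `Cc1cc(Nc2cc(-c3ccccc3)[nH]n2)n2nc(SCc3cccc(Br)c3)nc2n1` — 5140 nM

All three compounds keep the shared core and differ only in the aryl group on a saturated chain carbon bound to a sulfur. In a functional assay on MCF7 cells (Homo sapiens) for inhibition, read by MTT assay, with a stated time of 72 h (on this read-out lower numbers stand for stronger inhibition and higher numbers for weaker inhibition), compound 1 gives 7290 nM, compound 2 gives 3470 nM and compound 3 gives 5140 nM. For the measured compounds named here, the one step that clears the scatter is a 2.1-fold lower number from compound 1 to compound 2 (0.32 log units; beyond the scatter); the others, a 1.4-fold lower number from compound 1 to compound 3 (0.15 log units; within the scatter) and a 1.5-fold higher number from compound 2 to compound 3 (0.17 log units; within the scatter), stay within it. Compound 3 therefore stands second highest of the three numbers, and nothing separates it from compound 1 or compound 2 with any confidence.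

Compound 4 `Cc1cc(Nc2cc(-c3ccccc3)[nH]n2)n2nc(SCc3ccc(F)cc3)nc2n1` is the next member. The change from compound 3 is 4-fluorophenyl in place of 3-bromophenyl on a saturated chain carbon bound to a sulfur. Going by the values given here, no measured step covers a bromine-to-fluorine exchange, but every step on this arm so far is of the same kind, an aryl swap at the same place, and two of the three are within the scatter while the third is only modest. On that basis the expected step of a 1.1-fold higher number from compound 3 to compound 4 (0.03 log units; within the scatter) is small, in no firm direction, and most likely within the scatter. Compound 4 is thus estimated at 5500 nM in this assay, with a range from 2500 nM to 12000 nM.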

Compound 4, half-maximal inhibitory concentration: 4020 nM
Beside the measured number, compound 4's estimate is 1.4-fold (0.14 log units) above it; measured number inside the range.
By their numbers in this assay, from the lowest: compounds 2, 4, 3 and 1 (each within the scatter of the next, the first and the last beyond it).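

In this assay, 4-fluorophenyl in place of 3-bromophenyl on a saturated chain carbon bound to a sulfur gives a 1.3-fold lower number from compound 3 to compound 4 (0.11 log units; within the scatter), and 4-fluorophenyl in place of 1-benzothiophen-3-yl gives a 1.2-fold higher number from compound 2 to compound 4 (0.06 log units; within the scatter); the simple fluorinated aryl group therefore cannot be separated from either the bromo-substituted or the fused aryl group at this position. The new exchange of fluoro in place of methyl on an aromatic carbon gives a 1.8-fold lower number from compound 1 to compound 4 (0.26 log units; within the scatter), also within the scatter, which leaves the step from compound 1 to compound 2 as the only separation among the four compounds, with compound 3 and compound 4 unresolved from their neighbours. No supporting data bear on why these aryl exchanges behave in this way.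

From the compounds shown here alone, the step from compound 3 to compound 4 changes both the halogen and its place on the aryl group, so the effect of each remains open. Also open is how this position responds when the aryl group gives way to an amine, a carboxylic acid or a longer chain, since every compound shown carries an aryl group there.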